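Pyridinyl versus benzofuranyl amides on arylpiperazine ethylamides

A few compounds are considered here, and "the series" means these few. Any claim that something is new, unique, unknown or untested is made for them only; others in the source may bear on it.

Measured so far:
compound 1, `Cc1ccc(N2CCN(CCNC(=O)c3cccnc3)CC2)cc1` — 295 nM
compound 2, `Cc1ccc(N2CCN(CCNC(=O)c3cc4ccccc4o3)CC2)c(C)c1` — 43.7 nM

In a functional assay for antagonist activity at Adrenergic receptor alpha-1 (Rattus norvegicus) (on this read-out lower numbers stand for tighter binding and higher numbers for weaker binding), compound 2 gives 43.7 nM, the lowest of the two numbers recorded. In this assay compound 1 gives 295 nM, a higher number by a margin beyond the scatter. For the measured compounds named here, the two differ in more than one place, so no single step between them can be separated out.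

Compound 3, `Cc1ccc(N2CCN(CCNC(=O)c3cccnc3)CC2)c(C)c1`, is not yet measured. It follows from compound 2 by one change: pyridin-3-yl in place of 1-benzofuran-2-yl on a carbonyl carbon. The pyridin-3-yl amide is the same one carried by compound 1, whose number in this assay is the weaker of the two recorded. On that basis the step is expected to run toward a higher number, that is toward weaker binding, and to be larger than the scatter rather than flat. The expected step from compound 2 to compound 3 is a 4.6-fold higher number from compound 2 to compound 3 (0.66 log units; beyond the scatter). For compound 3 in this assay the estimate is 200 nM, with a range from 60 nM to 650 nM.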

Compound 3, dissociation constant: 1150 nM
The estimate for compound 3 lay 5.8-fold (0.76 log units) below the measured number; the measured number lies above the stated range.
By their numbers in this assay, from the lowest: compound 2; then compound 1; then compound 3.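

Within the pyridin-3-yl and 1-benzofuran-2-yl pair, the substituent on the carbonyl carbon now has a single-change reading: in this assay, pyridin-3-yl in place of 1-benzofuran-2-yl gives a 26-fold higher number from compound 2 to compound 3 (1.42 log units; beyond the scatter) as a large step beyond the scatter, so this position is far from indifferent to the change. With pyridin-3-yl held on the carbonyl carbon, methyl in place of hydrogen on an aromatic carbon gives a 3.9-fold higher number from compound 1 to compound 3 (0.59 log units; beyond the scatter) in the same assay, a modest step that is also beyond the scatter and runs toward weaker binding, so the added methyl does not offset the loss seen with pyridin-3-yl. The data at hand offer no measurement that accounts for either step.

The compounds shown read the methyl change with pyridin-3-yl only, so its size and direction with 1-benzofuran-2-yl on the carbonyl carbon remain open. Also open, on these data alone, is whether the fused six-membered carbon ring of 1-benzofuran-2-yl is needed for the lower number, a question that furan-2-yl on the same carbonyl carbon would address, while phenyl there would separate the ring nitrogen of pyridin-3-yl from the ring itself.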